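The source may report more compounds than this note shows. Statements on the series, on what has been measured and on what is new or still open speak of the compounds shown alone.

Notes on the series. In a physicochemical assay for lipophilicity (on this read-out higher numbers stand for higher lipophilicity and lower numbers for lower lipophilicity), compound 1 (`CCCCCCCN(CCCCCSc1nc(O)c2ccccc2n1)C(=O)Nc1ccc(F)cc1F`) gives 6.17, compound 2 (`CCCCCCCN(CCCCCSc1ncccn1)C(=O)Nc1ccc(F)cc1F`) gives 5.41 and compound 3 (`CCCCCCCN(CCCCCSc1nc(N)c2c[nH]nc2n1)C(=O)Nc1ccc(F)cc1F`) gives 5.74. Compound 3 therefore stands in the middle of the three, clear of both neighbours.

The next compound is compound 4 (`CCCCCCCN(CCCCCSc1nc(N)c2c[nH]nc2n1)C(=O)NC(C)C`), which differs from compound 3 by isopropyl in place of 2,4-difluorophenyl on an amide-type nitrogen. Among the compounds with values here, no measured step touches this position. All three measured steps change the group on the sulfur, so they offer only an indirect guide: a number 0.76 log units lower from compound 1 to compound 2 (beyond the scatter), a number 0.43 log units lower from compound 1 to compound 3 (beyond the scatter) and a number 0.33 log units higher from compound 2 to compound 3 (beyond the scatter). In each of these, the compound whose group has fewer heavy atoms carries the lower number, and none of the three compounds goes against this. The same reading applied to the new change points downward in this assay. From the compounds shown here alone, the largest measured step, a number 0.76 log units lower from compound 1 to compound 2 (beyond the scatter), serves as the reference for size, and a somewhat larger step seems likely, though this remains uncertain because the position is untested.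

The expected change is a number 0.94 log units lower from compound 3 to compound 4 (beyond the scatter). For compound 4 the estimated value is 4.8, with an expected range from 4.2 to 5.4.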

Compound 4, partition coefficient: 5.14
For compound 4 the middle estimate is 0.34 log units below the measured one; low and high end bracket the measured number.
By their numbers in this assay, from the lowest: compounds 4 and 2 (each within the scatter of the next); then compound 3; then compound 1.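

Working notes. In this assay the amide-type nitrogen now has a measured step of its own, with isopropyl in place of 2,4-difluorophenyl giving a number 0.60 log units lower from compound 3 to compound 4 (beyond the scatter) as a modest change, so the read-out moves with the group at this position as well as with the group on the sulfur. Within the data shown here, the step also runs the same way as those on the sulfur: the group with fewer heavy atoms, here 3 against 8, carries the lower number, and no single-place pair among the four compounds goes against this. Nothing on hand explains why the number falls at this position.

This one change removes the aromatic ring and the fluorine atoms and lowers the heavy-atom count all together, so the compounds shown do not say which of these the step follows, and an unsubstituted phenyl, a cyclohexyl or a longer chain such as n-hexyl on the amide-type nitrogen would be needed to pull them apart. From the compounds shown here alone, it also stays open whether a step of this size holds with the 4-hydroxyquinazolin-2-yl or pyrimidin-2-yl group on the sulfur.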